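Fluorine on the Aniline Ring of Styrylsulfonamides

This account rests on a few compounds, and the source may have more. Where it says the series, first, only, none or still open, it means among the compounds named here.

Measured compounds:
Compound 1, `COc1ccc(NS(=O)(=O)/C=C/c2c(F)c(F)c(F)c(F)c2F)cc1F`, 10000 nM
Compound 2, `COc1ccc(NS(=O)(=O)/C=C/c2c(OC)cc(OC)cc2OC)cc1`, 200 nM
Compound 3, `COc1ccc(NS(=O)(=O)/C=C/c2c(F)c(F)c(F)c(F)c2F)cc1`, 10000 nM

In a functional assay on DU-145 cells (Homo sapiens) for cytotoxicity, read by trypan blue exclusion, with a stated time of 96 h (a higher number here means a weaker inhibitor, a lower number a stronger inhibitor), compound 2 gives the lowest number of the three, and its separation from compound 1 and from compound 3 lies beyond the scatter. The difference between the cores of compound 2 and compound 3 is not broken down here. From compound 3 to compound 1 the change is fluoro in place of hydrogen on an aromatic carbon; that step gave no change at the digits printed from compound 3 to compound 1 (within the scatter).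

Compound 4, `COc1cc(OC)c(/C=C/S(=O)(=O)Nc2ccc(OC)c(F)c2)c(OC)c1`, has not yet been measured. It differs from compound 2 by fluoro in place of hydrogen on an aromatic carbon, the same change that led from compound 3 to compound 1. Because no change at the digits printed from compound 3 to compound 1 (within the scatter) showed no movement, a step of similar size, a 1.1-fold higher number from compound 2 to compound 4 (0.04 log units; within the scatter), is expected in this assay. The estimated value for compound 4 is 220 nM, with a range from 90 nM to 600 nM.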

Compound 4, half-maximal inhibitory concentration: 200 nM
Estimate against measurement, compound 4: 1.1-fold (0.04 log units) above; low and high end bracket the measured number.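

In this assay, fluoro in place of hydrogen on an aromatic carbon gave no change at the digits printed from compound 2 to compound 4 (within the scatter), and this agrees with the same change on the other core: the same change on two cores in this assay, no change at the digits printed (within the scatter) from compound 3 to compound 1 and no change at the digits printed (within the scatter) from compound 2 to compound 4, 1.0-fold (0.00 log units) apart, within the scatter of two such steps

In these two pairs, then, the change from 4-methoxyphenyl to 3-fluoro-4-methoxyphenyl carried from one core to the other, leaving the number in place both times. Among these compounds, it rests on only two cores, a single place on the ring and a single cell assay, so it does not show that the change would stay silent on any further core, nor why it left the number in place.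

The compounds shown leave open whether chloro, a nitrile or an amine at that same place would move the number. They also leave open what an ethoxy group in place of the methoxy group would do on either core.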